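Hydrogen in place of methyl: compound 2 to compound 3

The source may hold more compounds than are shown below. What is called first, only, known or untested is meant among the compounds shown, and "the series" means these compounds.

Compound 1 `CC1=CCC[C@](C)(CC/C(C)=C/CC2=C(O)C(=O)C=C(N[C@H](C(=O)O)[C@@H](C)O)C2=O)[C@@H]1C` and compound 2 `C=C1[C@H](C)CCC[C@]1(C)CC/C(C)=C/CC1=C(O)C(=O)C=C(N[C@H](C(=O)O)[C@@H](C)O)C1=O` carry the same amino-acid substituent on the shared core and differ only in the ring-bearing chain. In an ADME assay on L1210 cells (Mus musculus) for cytotoxicity, with a stated time of 48 h (a lower number here means a stronger inhibitor, a higher number a weaker inhibitor), compound 1 gives only a limit, > 10 ug/mL. In this assay compound 2 likewise gives only a limit, > 10 ug/mL. The step that the two limits leave unreadable from compound 1 to compound 2 is therefore not readable in size or direction. Compound 2 stands at the limit of > 10 ug/mL in this assay, at which 2 of the 2 values shown sit, so no measured value in the series is a number. Compound 3 `C=C1[C@H](C)CCC[C@]1(C)CC/C(C)=C/CC1=C(O)C(=O)C=C(N[C@@H](CO)C(=O)O)C1=O` differs from compound 2 in hydrogen in place of methyl on a saturated chain carbon bound to an oxygen on a saturated carbon and a saturated chain carbon. Within the data shown here, no measured pair carries this change, and the one measured step, a step that the two limits leave unreadable from compound 1 to compound 2, concerns a different group and is unreadable. Compound 3 is therefore expected to remain at the same limit, with the step that the limit leaves unreadable from compound 2 to compound 3 expected to be none beyond the scatter. Compound 3 is estimated at 15 ug/mL, within 8 ug/mL to 40 ug/mL.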

Compound 3, half-maximal inhibitory concentration: > 10 ug/mL
Compound 3: only a limit was reported (the forecaster's own chance of this, stated with the estimate: 80%); the middle value lies beyond the limit too.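

Compound 2 and compound 3 both rest on limits in this assay, so no step can be read between them: the limit of > 10 ug/mL in this assay, at which 3 of the 3 values shown sit.

The compounds shown leave open what number any of the three would reach, and whether hydrogen in place of methyl shifts it at all.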